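The source may hold more compounds than are shown below. What is called first, only, known or untested is meant among the compounds shown, and "the series" means these compounds.

In a functional assay on the whole organism (strain Swiss albino) for inhibition, with Mus musculus as the target, read by paw edema, with stated times of 30 min and 270 min, at a dose of 100 mg/kg by the subcutaneous route (on this read-out higher numbers stand for more inhibition at the one dose given (going by the name of the read-out) and lower numbers for less inhibition), compound 1 `Cc1ccc(-c2cc(C(=O)Oc3ccc(C(C)(C)C)cc3)n(Cc3ccccc3)n2)cc1` gives 50%, while compound 2 `Cc1ccc(-c2cc(C(=O)Oc3ccc(C(C)C)cc3)n(Cc3ccccc3)n2)cc1` gives 29%, the lowest of the two numbers. Within the data shown here, the only measured step, a number 21 percentage points lower from compound 1 to compound 2 (beyond the scatter), alters the same aromatic carbon that changes here, but it concerns a different pair of groups and so offers only weak guidance. Compound 3 `CCCCCCCOc1ccc(OC(=O)c2cc(-c3ccc(C)cc3)nn2Cc2ccccc2)cc1` carries heptyloxy in place of isopropyl on an aromatic carbon. Among the measured compounds shown here, no measured step includes a heptyloxy group, so the expectation rests on compound 2 alone and is broad. For compound 3 the estimate is 38%, ranging from 15% to 62%. That estimate means an expected step of a number 9 percentage points higher from compound 2 to compound 3 (within the scatter).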

Compound 3, a percentage reported as inhibition, in the whole organism at one dose (the size of the read-out at that dose, not a potency): 10%
Compound 3: middle estimate off by 28 percentage points, on the high side, and the stated range ends above it.
By their numbers in this assay, from the lowest: compound 3; then compound 2; then compound 1.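

In this assay, replacing isopropyl with heptyloxy gives a number 19 percentage points lower from compound 2 to compound 3 (beyond the scatter), and replacing tert-butyl with heptyloxy gives a number 40 percentage points lower from compound 1 to compound 3 (beyond the scatter). The earlier step suggested that one more methyl on this carbon goes with a higher number, but the much larger heptyloxy group does not continue that rise and instead gives the lowest number of the three. Nothing measured here gives a reason for this.

As far as these compounds go, it remains open whether the oxygen or the chain length matters: heptyloxy brings both at once, and a methoxy group or a plain heptyl chain would separate them.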